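A few compounds are considered here, and "the series" means these few. Any claim that something is new, unique, unknown or untested is made for them only; others in the source may bear on it.

- Compound 1 `O=C(O)CCC/C=C1/C[C@H]2C[C@@H](O)[C@H](/C=N\OC(c3ccccc3)c3ccccc3)[C@H]2C1`: 23000 nM
- Compound 2 `O=C(O)CCC/C=C1/C[C@H]2C[C@@H](O)[C@H](/C=N/OCc3ccc(F)cc3)[C@H]2C1`: 14000 nM

In a functional assay for agonist activity, with Homo sapiens as the target (on this read-out higher numbers stand for weaker inhibition and lower numbers for stronger inhibition), compound 2 gives 14000 nM. Among the measured compounds shown here, that number lies within the usual scatter of the one for compound 1, so the two cannot be ranked. Compound 3 `O=C(O)CCC/C=C1/C[C@H]2C[C@@H](O)[C@H](/C=N/OCc3ccc4ccccc4c3)[C@H]2C1` has naphthalen-2-yl in place of 4-fluorophenyl on a saturated chain carbon bound to an oxygen. For the measured compounds named here, no measured pair isolates this change, so the evidence is thin. Compound 1, with a different group, still gives 23000 nM, so no shift beyond the scatter is expected in this assay. The estimated change is a 1.2-fold lower number from compound 2 to compound 3 (0.07 log units; within the scatter). For compound 3, the expected value is 12000 nM, with an estimated range of 4000 nM to 32000 nM.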

Compound 3, half-maximal inhibitory concentration: 2200 nM
For compound 3 the middle estimate is 5.5-fold (0.74 log units) above the measured one; the whole stated range lies above it.
By their numbers in this assay, from the lowest: compound 3; then compounds 2 and 1 (each within the scatter of the next).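

In this assay, exchanging the 4-fluorophenyl group for naphthalen-2-yl gives a 6.4-fold lower number from compound 2 to compound 3 (0.80 log units; beyond the scatter), so the read-out at this position does respond to the group it carries. The earlier compounds shown here offered no step that isolated a single change. No evidence here explains this shift. Among the compounds shown here, what remains open is how far the shift depends on the second aromatic ring, since this is only one pair. A plain phenyl, a naphthalen-1-yl or a quinolin-2-yl group at this place could help to settle that.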